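The source may hold more compounds than are shown below. What is called first, only, known or untested is meant among the compounds shown, and "the series" means these compounds.

Compound 1 `COc1c(Nc2ccc(S(C)(=O)=O)cc2F)ncnc1OC1C[C@@H]2COC[C@@H](C1)N2C(=O)OC1(C)CC1` and compound 2 `CC1(COC(=O)N2CC3COCC(C2)C3Oc2ncnc(Nc3ccc(C#N)cc3Cl)c2F)COC1` were both tested in a functional assay on HEK293 cells for agonist activity at Glucose-dependent insulinotropic receptor (Homo sapiens), read by cAMP accumulation, with a stated time of 30 min; a higher number here means that more compound is needed for the effect, a lower number that less compound is needed. Compound 1 gives 97 nM, and compound 2 gives 188 nM. Of these two numbers compound 2 holds the larger one, but its gap to compound 1 lies within the scatter, so the two should be read as alike. Compound 3 `CC1(OC(=O)N2CC3COCC(C2)C3Oc2ncnc(Nc3ccc(C#N)cc3Cl)c2F)CCC1` differs from compound 2 by 1-methylcyclobutyl in place of (3-methyloxetan-3-yl)methyl on an oxygen next to a carbonyl group. Among the compounds with values here, no measured pair shows what this change does. A step of a 1.4-fold lower number from compound 2 to compound 3 (0.16 log units; within the scatter) is expected, which would stay within the scatter. Compound 3 is therefore estimated at 130 nM, with a range from 40 nM to 420 nM.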

Compound 3, half-maximal effective concentration: 10 nM
Beside the measured number, compound 3's estimate is 13-fold (1.11 log units) above it; measured number outside the range, below it.
By their numbers in this assay, from the lowest: compound 3; then compounds 1 and 2 (each within the scatter of the next).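

This position, on an oxygen next to a carbonyl group, proves highly sensitive: in this assay, 1-methylcyclobutyl in place of (3-methyloxetan-3-yl)methyl gives a 19-fold lower number from compound 2 to compound 3 (1.27 log units; beyond the scatter). Both groups carry a four-membered non-aromatic ring, so a modest structural change can shift this number strongly. No available measurement explains the size of this step. From the compounds shown here alone, the ring oxygen and the way the ring is attached change together here, so their separate contributions remain open. Also open, going by these compounds, is how 1-methylcyclopentyl or an amine such as 1-methylazetidin-3-yl would behave at this place.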